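A few compounds are considered here, and "the series" means these few. Any claim that something is new, unique, unknown or untested is made for them only; others in the source may bear on it.

Measured so far:
compound 1 `CCCCCCCCCCCCCCCOC(=O)CCC(=O)N1CCN(CCCOc2cc3c(Nc4ccc(F)c(Cl)c4)ncnc3cc2OC)CC1` — 85.5%
compound 2 `CCCCCCCCCCCCCCCCOC(=O)CCC(=O)N1CCN(CCCOc2cc3c(Nc4ccc(F)c(Cl)c4)ncnc3cc2OC)CC1` — 82.6%

In a functional assay on A549 cells (Homo sapiens) for cytotoxicity, read by MTT assay, with a stated time of 24 h, tested at 40 uM (a higher number here means a weaker effect of the compound at the concentration tested, a lower number a stronger effect), compound 1 gives 85.5% and compound 2 gives 82.6%. Compound 2 holds the lower of the two numbers, but the step of a number 2.9 percentage points lower from compound 1 to compound 2 (within the scatter) keeps the two within the scatter, so no order can be read from them.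

Compound 3 `CCCCCCCCCCCCCCCCCCOC(=O)CCC(=O)N1CCN(CCCOc2cc3c(Nc4ccc(F)c(Cl)c4)ncnc3cc2OC)CC1` has not been measured. Within the data shown here, it differs from compound 2 by ethyl in place of hydrogen on a saturated chain carbon, ten or more bonds along the chain from an oxygen next to a carbonyl group, the same kind of change as the only measured step, which was a number 2.9 percentage points lower from compound 1 to compound 2 (within the scatter) and lay within the scatter. No change beyond the scatter is therefore expected from compound 2 to compound 3, with a number 0.6 percentage points lower from compound 2 to compound 3 (within the scatter) as the estimated step. Compound 3 is estimated at 82%, within 70% to 94%.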

Compound 3, a percentage reported as activity, at one concentration (the size of the read-out at that concentration, not a potency): 91%
For compound 3 the middle estimate is 9 percentage points below the measured one; measured number inside the range.
By their numbers in this assay, from the lowest: compounds 2, 1 and 3 (each within the scatter of the next).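

In this assay ethyl in place of hydrogen on this saturated chain carbon gives a number 8.4 percentage points higher from compound 2 to compound 3 (within the scatter) and propyl in the same place gives a number 5.5 percentage points higher from compound 1 to compound 3 (within the scatter) so these wider changes, like the methyl step, stay inside the scatter. No dependence on chain length can be read at this position from these three compounds. Nothing available bears on why the numbers fall as they do. Still open, going by these compounds, is whether a much longer chain, or an amine or a carboxylic acid in place of the chain, would move the number beyond the scatter.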